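Swapping an aryl group at the core of compound 1

This account rests on a few compounds, and the source may have more. Where it says the series, first, only, none or still open, it means among the compounds named here.

Compound 1, `Cc1ccccc1-c1cc(-c2ccc(Cl)o2)cc(-c2ccsc2)n1`, gives 18400 nM in a functional assay on K562 cells (Homo sapiens) for cytotoxicity, in the presence of a further agent that is not named here; a lower number here means a stronger inhibitor, a higher number a weaker inhibitor.
Compound 2, `Clc1ccc(-c2cc(-c3ccoc3)cc(-c3ccsc3)n2)cc1`, gives 730 nM in this assay.
Compound 3, `Clc1ccc(-c2cc(-c3ccco3)cc(-c3cccs3)n2)cc1`, gives > 100000 nM in this assay, which is a limit of the assay and not a number; this is the case described as the limit of > 100000 nM in this assay, at which 1 of the 3 values shown sits.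

Among the two numbers that are known, compound 1 carries the higher one, and compound 2 carries a lower one, with a gap that lies beyond the usual scatter. Compound 4, `Clc1ccc(-c2cc(-c3ccsc3)nc(-c3ccccn3)c2)o1`, is not yet measured. Its change from compound 1 is pyridin-2-yl in place of 2-methylphenyl on an aromatic carbon, at a position next to the ring nitrogen of the shared core. Within the data shown here, no measured pair shows this change, so the expectation rests on the spread of the known values alone. For compound 4 a somewhat lower number than for compound 1 is expected in this assay, a step of a 3.1-fold lower number from compound 1 to compound 4 (0.49 log units; beyond the scatter) that is modest and uncertain. The estimate for compound 4 is 6000 nM, expected to fall between 1200 nM and 30000 nM.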

Compound 4, half-maximal inhibitory concentration: 21900 nM
The estimate for compound 4 lay 3.7-fold (0.56 log units) below the measured number; low and high end bracket the measured number.
By their numbers in this assay, from the lowest: compound 2; then compounds 1 and 4 (each within the scatter of the next). At a limit, above all of these: compound 3.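

Putting pyridin-2-yl in place of 2-methylphenyl on this aromatic carbon, next to the ring nitrogen of the shared core, gives a 1.2-fold higher number from compound 1 to compound 4 (0.08 log units; within the scatter) in this assay. Among these compounds, this is the first measured pair that differs in only one place, and it shows that, in this read-out, these two six-membered aromatic rings cannot be told apart here, even though pyridin-2-yl carries a ring nitrogen and lacks the methyl group of 2-methylphenyl. Nothing measured here offers a reason for this outcome.

From the compounds shown here alone, it remains open how the position responds to groups of a different kind, such as an amine, a carboxylic acid or a longer alkyl chain. Going by these compounds, it also remains open whether pyridin-3-yl would behave like pyridin-2-yl, and whether the same swap would read alike with other groups in place of 5-chlorofuran-2-yl and thiophen-3-yl.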